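Amide nitrogen substituent in the shared core series

The source may hold more compounds than are shown below. What is called first, only, known or untested is meant among the compounds shown, and "the series" means these compounds.

compound 1 `Cc1ccc(N2C(=O)COc3ccc(-c4cnc5ccccc5c4)cc32)cc1`: > 40000 nM (a limit of the assay)
compound 2 `O=C1COc2ccc(-c3cnc(Cl)c(NS(=O)(=O)c4ccc(F)cc4)c3)cc2N1c1ccc(F)cc1`: 34200 nM

In a functional assay on HCT-116 cells (Homo sapiens) for antiproliferative activity, read by MTT assay, with a stated time of 72 h (a higher number here means a weaker inhibitor, a lower number a stronger inhibitor), compound 1 stands only at a limit, > 40000 nM, which is the limit of > 40000 nM in this assay, at which 1 of the 2 values shown sits. Among the compounds with values here, compound 2 gives 34200 nM in this assay; it differs from compound 1 in several places, so no single step joins them. Compound 3 `O=C1COc2ccc(-c3cnc4ccccc4c3)cc2N1C1CCCCC1` has not yet been measured. It carries cyclohexyl in place of 4-methylphenyl on an amide-type nitrogen in a ring. With compound 1 at a limit, no shift beyond the scatter is expected in either direction, and the step of a number no higher from compound 1 to compound 3 (the limit leaves the size open) is estimated as small. Compound 3 is expected to give 40000 nM, within 15000 nM to 100000 nM.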

Compound 3, half-maximal inhibitory concentration: > 40000 nM
Compound 3: no number, only a limit; the forecaster's own chance of this, stated with the estimate: 55%; the middle value lies on the limit itself.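

In this assay compound 3 gives > 40000 nM, a limit of the assay, as compound 1 also does, so no step between compound 1 and compound 3 can be read: the limit of > 40000 nM in this assay, at which 2 of the 3 values shown sit.

Going by these compounds, how cyclohexyl and 4-methylphenyl on the amide-type nitrogen compare in this assay stays open.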